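This account rests on a few compounds, and the source may have more. Where it says the series, first, only, none or still open, it means among the compounds named here.

In a toxicity assay on the whole organism with Rattus norvegicus as the target, at a dose of 100 mg/kg by the oral route (on this read-out lower numbers stand for a weaker effect and higher numbers for a stronger effect at the one dose given), compound 3 `Brc1ccc(OCC2=NCCO2)cc1` gives 60%, the top of the three recorded numbers, although its gap to compound 1 lies within the scatter. Compound 1 `COc1ccc(OCC2=NCCO2)cc1` gives 50%, and compound 2 `Clc1ccc(OCC2=NCCO2)cc1` gives 30%. Compound 4 `Fc1ccc(OCC2=NCCO2)cc1` differs from compound 3 by fluoro in place of bromo on an aromatic carbon. The measured step that bears most directly on this swap is the only one exchanging one halogen for another: a number 30 percentage points higher from compound 2 to compound 3 (beyond the scatter). The other two steps, a number 20 percentage points lower from compound 1 to compound 2 (beyond the scatter) and a number 10 percentage points higher from compound 1 to compound 3 (within the scatter), replaced methoxy rather than a halogen and speak less directly. Since that halogen exchange produced a modest change, a modest fall is expected here: a number 25 percentage points lower from compound 3 to compound 4 (beyond the scatter). Compound 4 is therefore estimated at 35%, with a range from 10% to 65%.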

Compound 4, a percentage reported as activity, at one dose (the size of the read-out at that dose, not a potency): 25%
The estimate for compound 4 lay 10 percentage points above the measured number; measured number inside the range.
By their numbers in this assay, from the lowest: compounds 4 and 2 (each within the scatter of the next); then compounds 1 and 3 (each within the scatter of the next).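

Fluoro in place of bromo gives a number 35 percentage points lower from compound 3 to compound 4 (beyond the scatter), the largest step seen at this position, whereas fluoro in place of chloro gives a number 5 percentage points lower from compound 2 to compound 4 (within the scatter), so these two halogens cannot be told apart here, and bromo stands apart from both. Fluoro in place of methoxy gives a number 25 percentage points lower from compound 1 to compound 4 (beyond the scatter), which places compound 4 with compound 2, clearly apart from compound 1. Nothing available explains why bromo differs from the two lighter halogens. As far as these compounds go, whether an amine or a carboxylic acid at this position would read like bromo and methoxy or like chloro and fluoro remains open.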